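The source may hold more compounds than are shown below. What is called first, only, known or untested is meant among the compounds shown, and "the series" means these compounds.

Three compounds have numbers in an assay on HEK293 cells for binding affinity to adenosine receptor A2b (Homo sapiens), read by radioligand binding; on this read-out lower numbers stand for stronger inhibition and higher numbers for weaker inhibition. Compound 1 `C=CCn1c(=O)[nH]c2[nH]cnc2c1=O` gives 461 nM. Compound 2 `Cn1cnc2c1c(=O)n(CC(=O)O)c(=O)n2C` gives 23500 nM. Compound 3 `COCn1c(=O)c2c(ncn2C)n(C)c1=O` gives 14000 nM, the second highest of the three numbers; its nearest neighbour is compound 2, and the two lie within the scatter of each other, while compound 1 is far off, with the step from compound 3 to compound 1 beyond the scatter.

Compound 4 `Cn1cnc2c1c(=O)n(CC#N)c(=O)n2C` has not yet been measured. It differs from compound 3 in one place: cyano in place of methoxy on a saturated chain carbon bound to an aromatic nitrogen. Among the compounds with values here, one measured step bears on this, the one at the same place from compound 2 to compound 3, where a carboxy group was exchanged for a methoxy group: a 1.7-fold lower number from compound 2 to compound 3 (0.22 log units; within the scatter). That exchange, like the present one, swapped one small group for another of the same size on the saturated chain carbon bound to an aromatic nitrogen, and the number hardly moved. On this basis no step beyond the scatter is expected in this assay, in either direction.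

Compound 4 is therefore estimated to give about 14000 nM, with a range from 5000 nM to 40000 nM, which means an expected step of no change at the digits printed from compound 3 to compound 4 (within the scatter).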

Compound 4, inhibition constant: 21600 nM
For compound 4 the middle estimate is 1.5-fold (0.19 log units) below the measured one; measured number inside the range.
By their numbers in this assay, from the lowest: compound 1; then compounds 3, 4 and 2 (each within the scatter of the next).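

In this assay, a third group at the saturated chain carbon bound to an aromatic nitrogen again shifts the number by no more than the scatter: cyano in place of methoxy gives a 1.5-fold higher number from compound 3 to compound 4 (0.19 log units; within the scatter), and cyano in place of carboxy gives a 1.1-fold lower number from compound 2 to compound 4 (0.04 log units; within the scatter). The position previously rested on a single exchange, whereas compound 2, compound 3 and compound 4 now give three pairs, and every one of those steps lies within the scatter, so carboxy, methoxy and cyano cannot be told apart here. Nothing available explains why these three groups read alike.

On these data alone, it remains open whether an amine, a longer chain such as propyl or a phenyl ring at this position would produce a step beyond the scatter, since all three groups seen so far give numbers that cannot be separated. Compound 1 differs from these compounds in more than one place, so the same exchanges on the core of compound 1 would be needed to learn whether this position is equally insensitive there.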